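This account rests on a few compounds, and the source may have more. Where it says the series, first, only, none or still open, it means among the compounds named here.

Measured so far:
- compound 1 `C=CCOn1c(-c2cccc(C#N)c2)nc(C)c1C(=O)OCC`: 5860 nM
- compound 2 `CCOC(=O)c1c(C)nc(-c2cccc(C#N)c2)n1OCc1ccc(C)cc1`: 6310 nM

In a functional assay on a cell-free system (plasma, Oryctolagus cuniculus) for inhibition, with stated times of 5 min, 1 min and 6 min (a lower number here means a stronger inhibitor, a higher number a weaker inhibitor), compound 2 gives 6310 nM, level with compound 1 within the scatter. Next is compound 3 `CCOC(=O)c1c(C)nc(-c2cccc(C#N)c2)n1OCc1ccc(C#N)cc1`, with cyano in place of methyl on an aromatic carbon, 4-methylbenzyl to 4-cyanobenzyl: cyano in place of methyl on an aromatic carbon. Among the measured compounds shown here, no measured step tests this exchange. The nearest evidence is a change at the same chain, vinyl to 4-methylphenyl, which gave a 1.1-fold higher number from compound 1 to compound 2 (0.03 log units; within the scatter). With so little evidence, no shift beyond the scatter is expected in this assay, and no direction can be favoured. The expected change is a 1.1-fold lower number from compound 2 to compound 3 (0.02 log units; within the scatter). Compound 3 is estimated at 6000 nM, within a range of 2500 nM to 14000 nM.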

Compound 3, half-maximal inhibitory concentration: 4240 nM
The estimate for compound 3 lay 1.4-fold (0.15 log units) above the measured number, and the stated range covers the measured number.
By their numbers in this assay, from the lowest: compounds 3, 1 and 2 (each within the scatter of the next).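

In this assay the exchange of 4-methylbenzyl for 4-cyanobenzyl gives a 1.5-fold lower number from compound 2 to compound 3 (0.17 log units; within the scatter) and thus tests this aromatic carbon directly. The comparison with the vinyl-bearing chain gives a 1.4-fold lower number from compound 1 to compound 3 (0.14 log units; within the scatter) and likewise stays within the scatter. This position therefore accepts either methyl or cyano without a shift beyond the scatter, and the three compounds read level. From the compounds shown here alone, whether an amine or a carboxylic acid at this aromatic carbon would move the number beyond the scatter remains open. No evidence available here bears on this result.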